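Ring-opened side chain on a quinolinone-type antagonist series

The compounds below may be only part of what the source reports. "The series", "measured", "known", "first", "only" and "open" are said of these compounds alone.

Compound 1 `O=C(COc1ccc2[nH]c(=O)c(-c3nccs3)c(CCc3ccccc3)c2c1)NC1(c2ccccc2)CC1` is the reference point of this small set. Going by the values given here, in a functional assay on HMC-1 cells for antagonist activity at adenosine receptor A2b (Homo sapiens), read by ELISA, with a stated time of 6 h (on this read-out lower numbers stand for stronger inhibition and higher numbers for weaker inhibition), compound 1 gives 1 nM, the only number so far. Two further compounds carry a different aryl group on the shared core and a 2-phenylpropan-2-yl group on the amide nitrogen: compound 2 `CC(C)(NC(=O)COc1ccc2[nH]c(=O)c(-c3ccccn3)c(CCc3ccccc3)c2c1)c1ccccc1` and compound 3 `CC(C)(NC(=O)COc1ccc2[nH]c(=O)c(-c3cccnc3)c(CCc3ccccc3)c2c1)c1ccccc1`. Among the compounds with values here, for compound 2 the result in this assay is recorded as "not determined" (no result reported), and for compound 3 likewise as "not determined" (no result reported), so neither offers a number to compare with compound 1, and no step between measured compounds can be drawn.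

Compound 4 `CC[C@H](NC(=O)COc1ccc2[nH]c(=O)c(-c3nccs3)c(CCc3ccccc3)c2c1)c1ccccc1` keeps the thiazolyl group and the phenethyl chain of compound 1 and changes only the amide substituent: 1-phenylpropyl in place of 1-phenylcyclopropyl on an amide-type nitrogen. Within the data shown here, since no measured step of this kind exists here, the size of the step from compound 1 to compound 4 can only be anticipated, and the expectation is a modest loss, a 3.0-fold higher number from compound 1 to compound 4 (0.48 log units; beyond the scatter), close to the scatter. Compound 4 is therefore expected to give about 3 nM in this assay, with a range from 0.7 nM to 15 nM.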

Compound 4, inhibition constant: 0.4 nM
Estimate against measurement, compound 4: 7.5-fold (0.88 log units) above; measured number outside the range, below it.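

In this assay, 1-phenylpropyl in place of 1-phenylcyclopropyl on the amide-type nitrogen gives a 2.5-fold lower number from compound 1 to compound 4 (0.40 log units; beyond the scatter) and so shows that the three-membered ring is not needed for a low number in this series. Both groups hold the same count of heavy atoms, yet the number still moves beyond the scatter, so this position responds to a change that leaves that count untouched. Nothing measured here accounts for the step.

Open, on these data alone, is whether the opposite configuration at the defined stereocentre of compound 4 would give a similar number. Also open, as far as these compounds go, is how a shorter chain, as in 1-phenylethyl, or a longer one, as in 1-phenylbutyl, would compare with the 1-phenylpropyl group on the same core.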